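Sulfonamide-Linked Benzylamines Against A2780 Growth

The source may hold more compounds than are shown below. What is called first, only, known or untested is meant among the compounds shown, and "the series" means these compounds.

Compound 1 `O=S(=O)(NCCNCc1cccc2ccccc12)c1cc(C(F)(F)F)cc(C(F)(F)F)c1`: 21000 nM
Compound 2 `O=S(=O)(NCCCNCc1ccccc1Cl)c1cc(C(F)(F)F)cc(C(F)(F)F)c1`: 9300 nM

In a functional assay on A2780 cells (Homo sapiens) for inhibition, read by MTT assay, with a stated time of 72 h (on this read-out higher numbers stand for weaker inhibition of growth and lower numbers for stronger inhibition of growth), compound 2 gives 9300 nM, the lower of the two numbers measured, and its gap to compound 1 lies beyond the scatter. Compound 3 `CC(C)(C)c1ccc(CNCCCNS(=O)(=O)c2cc(C(F)(F)F)cc(C(F)(F)F)c2)cc1` carries 4-(tert-butyl)phenyl in place of 2-chlorophenyl on a saturated chain carbon bound to an amine nitrogen. Going by the values given here, no measured pair shows the effect of this change, so the expectation rests on compound 2 alone. A moderate step toward stronger inhibition is expected, a 1.6-fold lower number from compound 2 to compound 3 (0.19 log units; within the scatter), though a result within the scatter would not surprise. On this basis compound 3 is estimated at 6000 nM, with a range from 2000 nM to 20000 nM.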

Compound 3, concentration for 50% growth inhibition: 2900 nM
Beside the measured number, compound 3's estimate is 2.1-fold (0.32 log units) above it, within the range that was stated.
By their numbers in this assay, from the lowest: compound 3; then compound 2; then compound 1.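

At this place, on a saturated chain carbon bound to an amine nitrogen, the choice of aryl group changes the result: in this assay, 4-(tert-butyl)phenyl in place of 2-chlorophenyl gives a 3.2-fold lower number from compound 2 to compound 3 (0.51 log units; beyond the scatter). This single step cannot separate losing the chlorine from gaining the tert-butyl group. Nothing available explains the gain. The compounds shown leave open how an unsubstituted phenyl or a 4-chlorophenyl would read here. They also leave open whether a longer chain would keep the gain seen with 4-(tert-butyl)phenyl.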